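Shortening the aryl alkyl chain of a carbamate lactone

This account rests on a few compounds, and the source may have more. Where it says the series, first, only, none or still open, it means among the compounds named here.

Measured compounds:
compound 1 `C=C1C(=O)OC[C@@H]1CCOC(=O)Nc1ccc(CCCC)cc1` — 1230 nM
compound 2 `C=C1C(=O)OC[C@H]1CCOC(=O)Nc1ccc(CCCC)cc1` — 620 nM

In a functional assay on RAW264.7 cells (Mus musculus) for inhibition, with a stated time of 30 min (on this read-out lower numbers stand for stronger inhibition and higher numbers for weaker inhibition), compound 1 gives 1230 nM and stands with the highest of the two numbers shown. Its nearest neighbour is compound 2, which gives 620 nM in this assay. Going by the values given here, the only measured step is a 2.0-fold lower number from compound 1 to compound 2 (0.30 log units; within the scatter), and the two compounds differ only in configuration as drawn, as the fact that compounds 1 and 2 differ only in the configuration as drawn records.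

Compound 3 `C=C1C(=O)OC[C@@H]1CCOC(=O)Nc1ccc(CC)cc1` has not yet been measured. It differs from compound 1 by hydrogen in place of ethyl on a saturated chain carbon, two bonds along the chain from an aromatic carbon. Among the compounds with values here, no measured step touches the alkyl chain on the aromatic ring: the one step available, from compound 1 to compound 2, concerns only the stereocentre and so gives no guide to the size or direction of the present change. The expectation for compound 3 in this assay is therefore anchored on compound 1 with a wide range, and it is estimated that a step of a 1.6-fold higher number from compound 1 to compound 3 (0.21 log units; within the scatter) follows, which is expected to stay close to the scatter. Compound 3 is expected to give 2000 nM in this assay, with a range from 700 nM to 6000 nM.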

Compound 3, half-maximal inhibitory concentration: 1260 nM
For compound 3 the middle estimate is 1.6-fold (0.20 log units) above the measured one; low and high end bracket the measured number.
By their numbers in this assay, from the lowest: compounds 2, 1 and 3 (each within the scatter of the next, the first and the last beyond it).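

Going by these compounds alone, the step on the alkyl chain, butyl to ethyl, is the first to touch this position, and in this assay it reads a 1.0-fold higher number from compound 1 to compound 3 (0.01 log units; within the scatter). For the configuration drawn in compound 1, the outer ethyl of the chain, with its 2 heavy atoms, can therefore give way to hydrogen with no difference that this read-out can separate from scatter, something the earlier stereochemical pair could not show. The one fact at hand about these compounds concerns configuration alone and does not bear on this chain step.

The compounds shown leave open whether the same holds with the stereocentre drawn as in compound 2, since ethyl appears here only with the configuration of compound 1. They also leave open how far the chain can be taken in either direction before the number in this assay moves beyond the scatter, whether with a methyl, with a longer chain such as hexyl, or with an amine or a carboxylic acid at the end of the chain.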